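Sulfonyl removal at the aryl amine of compound 2

This account rests on a few compounds, and the source may have more. Where it says the series, first, only, none or still open, it means among the compounds named here.

Three analogues sharing one core have been measured in an assay on isolated protein for inhibition of lactase/phlorizin hydrolase (Rattus norvegicus), read by colorimetric assay; on this read-out higher numbers stand for weaker inhibition and lower numbers for stronger inhibition. Compound 1 `Cc1ccc(S(=O)(=O)Nc2ccc3c(c2)C(=O)N(Cc2ccccc2)C3=O)cc1` gives only a limit, > 200000 nM. Compound 2 `Cc1ccc(S(=O)(=O)Nc2ccc3c(c2)C(=O)N(CCNc2ccccc2)C3=O)cc1` gives 177000 nM and compound 3 `Cc1ccc(S(=O)(=O)Nc2ccc3c(c2)C(=O)N(CCOc2cccc(O)c2)C3=O)cc1` gives 111000 nM. Compound 2 thus holds the higher of the two numbers, with compound 3 as its nearest neighbour: a 1.6-fold lower number from compound 2 to compound 3 (0.20 log units; within the scatter). The other steps, an at least 1.1-fold lower number from compound 1 to compound 2 (0.05 log units; that floor lies within the scatter) and an at least 1.8-fold lower number from compound 1 to compound 3 (0.25 log units; that floor lies within the scatter), are likewise small. All three steps alter the chain on the amide-type nitrogen in the ring, while the (4-methylphenyl)sulfonyl group stays in place in every case.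

Compound 4 `Nc1ccc2c(c1)C(=O)N(CCNc1ccccc1)C2=O` differs from compound 2 in exactly that part: hydrogen in place of (4-methylphenyl)sulfonyl on a nitrogen on an aromatic ring. Within the data shown here, no measured step touches this position, so the series supplies no scale for the change. Every measured number sits close to the limit (the limit of > 200000 nM in this assay, at which 1 of the 3 values shown sits), and a step toward weaker inhibition is expected, of size a 1.7-fold higher number from compound 2 to compound 4 (0.23 log units; within the scatter). For compound 4 the expected value in this assay is 300000 nM, with a range from 100000 nM to 1000000 nM.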

Compound 4, half-maximal inhibitory concentration: > 200000 nM
Compound 4 was reported as a limit; the forecaster's own chance of this, stated with the estimate: 55%; the middle value does not contradict the limit.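

Hydrogen in place of (4-methylphenyl)sulfonyl on a nitrogen on an aromatic ring is the first change at this position, and in this assay it reads as an at least 1.1-fold higher number from compound 2 to compound 4 (0.05 log units; that floor lies within the scatter). Compound 4 gives > 200000 nM, which is a limit of the assay and not a number. The change shows no sign of stronger inhibition, but the size of any loss stays unfixed, with only a floor to read at this position: the limit of > 200000 nM in this assay, at which 2 of the 4 values shown sit.

Going by these compounds, one pair cannot settle whether the (4-methylphenyl)sulfonyl group contributes to inhibition at all, and the same change on the 3-hydroxyphenoxy chain of compound 3 remains unknown. Also open, on these data alone, is how smaller groups on this nitrogen, such as acetyl or methanesulfonyl, or a carboxylic acid on the aromatic ring of the sulfonyl group, would read.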